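The source may report more compounds than this note shows. Statements on the series, on what has been measured and on what is new or still open speak of the compounds shown alone.

Compound 3 `COc1ccccc1-c1cn(C[C@H](O)[C@H]2OC(=O)C(OCc3ccccc3)=C2OCc2ccccc2)nn1` stands at the far end of the numbers gathered so far: in a functional assay on HCT-116 cells (Homo sapiens) for antiproliferative activity, read by MTT assay, with a stated time of 72 h (on this read-out lower numbers stand for stronger inhibition and higher numbers for weaker inhibition), compound 3 gives > 100000 nM, which is a limit of the assay rather than a measured number. Its two close relatives are compound 1 `CC(C)(C)c1cn(C[C@H](O)[C@H]2OC(=O)C(OCc3ccccc3)=C2OCc2ccccc2)nn1`, which gives 28300 nM in this assay, and compound 2 `O=C1O[C@H]([C@@H](O)Cn2cc(CNS(=O)(=O)c3ccc(F)cc3)nn2)C(OCc2ccccc2)=C1OCc1ccccc1`, which gives 22900 nM. Compound 4 `O=C1O[C@H]([C@@H](O)Cn2ccnn2)C(OCc2ccccc2)=C1OCc1ccccc1` differs from compound 3 by hydrogen in place of 2-methoxyphenyl on an aromatic carbon. Among the measured compounds shown here, two measured steps bear on this change, an at least 3.5-fold higher number from compound 1 to compound 3 (0.54 log units; beyond the scatter) and an at least 4.3-fold higher number from compound 2 to compound 3 (0.64 log units; beyond the scatter), both of which end at the limit of > 100000 nM in this assay, at which 1 of the 3 values shown sits. Since adding the 2-methoxyphenyl pushed the number up in both cases, taking it away is expected to bring it back down. Compound 4 is therefore expected to give about 40000 nM in this assay, with a range of 15000 nM to 100000 nM, an expected step of an at least 2.5-fold lower number from compound 3 to compound 4 (0.39 log units; beyond the scatter).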

Compound 4, half-maximal inhibitory concentration: > 100000 nM
Compound 4 ended at the assay's limit; the forecaster's own chance of this, stated with the estimate: 30%; middle value at least 2.5-fold (0.39 log units) from the limit.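

In this assay compound 4 stands at a limit of the assay, as compound 3 does, so the step between them cannot be read: the limit of > 100000 nM in this assay, at which 2 of the 4 values shown sit.

Hydrogen in place of tert-butyl gives an at least 3.5-fold higher number from compound 1 to compound 4 (0.54 log units; beyond the scatter), and hydrogen in place of (((4-fluorophenyl)sulfonyl)amino)methyl gives an at least 4.3-fold higher number from compound 2 to compound 4 (0.64 log units; beyond the scatter). Removing the 2-methoxyphenyl thus brought no readable return, and among the compounds shown, only those two groups on this aromatic carbon give a number short of the limit.

On these data alone, whether an amine, a carboxylic acid or a longer alkyl chain on this carbon would also do so remains open. As far as these compounds go, how far compound 3 and compound 4 lie beyond the limit also remains open.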